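Compound 4 without the methoxymethoxy group: expected cytotoxicity

A few compounds are considered here, and "the series" means these few. Any claim that something is new, unique, unknown or untested is made for them only; others in the source may bear on it.

Compound 1 `COCOc1cccc(C(=O)/C=C/c2ccc3c(c2)B(O)OC3)c1` is the reference here, read in an ADME assay on L929 cells (Mus musculus) for cytotoxicity, read by resazurin assay, with a stated time of 72 h; a lower number here means a stronger inhibitor, a higher number a weaker inhibitor. In this assay compound 1 gives > 10 ug/mL, which is a limit and not a number. Compound 2 `CCc1ccc(C(=O)/C=C/c2ccc3c(c2)B(O)OC3)cc1` gives > 10 ug/mL, also a limit. Compound 3 `O=C(/C=C/c1ccc2c(c1)B(O)OC2)c1ccccn1` gives > 10 ug/mL, again a limit. Compound 1 therefore has no number of its own, and its place is shared: the series shows (the limit of > 10 ug/mL in this assay, at which 3 of the 3 values shown sit). No ranking can be drawn among these three compounds, and no measured pair differs in one place only, so no measured step is available to size a change.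

Compound 4 `O=C(/C=C/c1ccc2c(c1)B(O)OC2)c1ccccc1` remains to be read. Relative to compound 1 it carries hydrogen in place of methoxymethoxy on an aromatic carbon, meta to a large group: hydrogen in place of methoxymethoxy on an aromatic carbon. In this assay no change beyond the scatter is expected, in either direction. The only support for this expectation is compound 1 at > 10 ug/mL, a limit that the other two measured compounds also reach. The expected change is a step that the limit leaves unreadable from compound 1 to compound 4, and a further limit reading is the likeliest outcome. In this assay the estimate for compound 4 is 15 ug/mL, expected to fall within 6 ug/mL to 40 ug/mL.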

Compound 4, half-maximal inhibitory concentration: > 10 ug/mL
Compound 4: no number, only a limit; the forecaster's own chance of this, stated with the estimate: 75%; the middle value is on the limit's open side.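

In this assay compound 4 gives > 10 ug/mL as a limit and not a number. Going by these compounds alone, no step from compound 1, compound 2 or compound 3 to compound 4 can be read, because all four compounds stand at one limit: the limit of > 10 ug/mL in this assay, at which 4 of the 4 values shown sit.

The compounds shown leave open how far apart these four lie, and whether any of the changed groups alters cytotoxicity.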